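Ester variation on a shared core: next step

The source may hold more compounds than are shown below. What is called first, only, known or untested is meant among the compounds shown, and "the series" means these compounds.

The series shares the core of compound 1 `CC1=C(C(=O)OCc2ccccc2)C(c2ccc(Cl)cc2Cl)NC(=O)N1CCCCC(=O)O`. In an ADME assay on MCF7 cells (Homo sapiens) for cytotoxicity, read by CellTiter-Glo, with a stated time of 24 h (a higher number here means a weaker inhibitor of growth, a lower number a stronger inhibitor of growth), compound 1 reports only the limit > 100000 nM, not a number. Compound 2 `COC(=O)CCCN1C(=O)NC(c2ccc(Cl)cc2Cl)C(C(=O)OCc2ccccc2)=C1C` carries a methoxycarbonyl in place of the carboxymethyl on a saturated chain carbon, three bonds along the chain from an amide-type nitrogen in a ring. In this assay compound 2 likewise reports only the limit > 300000 nM, not a number. The step that the two limits leave unreadable from compound 1 to compound 2 therefore cannot be read; it rests on the limit of > 100000 nM in this assay, at which 1 of the 2 values shown sits, and (the limit of > 300000 nM in this assay, at which 1 of the 2 values shown sits). Compound 3 `CC1=C(C(=O)OCc2ccccc2)C(c2ccc(Cl)cc2Cl)NC(=O)N1CCCC(=O)OCc1ccccn1` is not yet measured and differs from compound 2 by pyridin-2-yl in place of hydrogen on a saturated chain carbon bound to an oxygen next to a carbonyl group. Going by the values given here, no measured step shows the effect of such a group at this place, and the one measured step is unreadable, so no direction beyond the scatter of this assay can be expected. Compound 3 is estimated at 200000 nM in this assay, with a range from 50000 nM to 500000 nM, most probably again reported only as a limit. The step of an at least 1.5-fold lower number from compound 2 to compound 3 (0.17 log units; that floor lies within the scatter) is thus expected to be small.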

Compound 3, concentration for 50% growth inhibition: > 100000 nM
Compound 3 gave a limit, no number (the forecaster's own chance of this, stated with the estimate: 80%); the middle value does not contradict the limit.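

In this assay, going by these compounds alone, compound 3 reports only a limit, > 100000 nM, not a number, so no step from compound 1 or compound 2 to compound 3 can be read. The compounds shown leave open whether any group at this chain end gives a readable number in this assay.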